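Benzyl triazole series: removing the benzyl methoxy group

The source may report more compounds than this note shows. Statements on the series, on what has been measured and on what is new or still open speak of the compounds shown alone.

Among the measured compounds shown here, compound 2 `COc1cccc(Cn2cc(-c3ccc4ccccc4c3)nn2)c1` is one of three compounds measured so far in a functional assay on B16 cells (Mus musculus) for cytotoxicity, read by MTT assay, with a stated time of 48 h; on this read-out lower numbers stand for stronger inhibition and higher numbers for weaker inhibition. In this assay compound 2 gives > 100000 nM, which is a limit of the assay and not a number. Compound 1 `COc1cccc(Cn2cc(-c3ccc(OC)c(OC)c3OC)nn2)c1` gives > 100000 nM, again a limit. Compound 3 `COc1ccc(C(O)c2cn(C[C@H]3COC(C)(C)O3)nn2)c(OC)c1OC` gives > 100000 nM, also a limit. Compound 2 thus stands where every value shown stands, at the limit of > 100000 nM in this assay, at which 3 of the 3 values shown sit. For the measured compounds named here, no step between two measured compounds is available. Compound 4 `c1ccc(Cn2cc(-c3ccc4ccccc4c3)nn2)cc1` differs from compound 2 by hydrogen in place of methoxy on an aromatic carbon. With every value shown being a limit, no direction can be read from the data; the expected step, a number no higher from compound 2 to compound 4 (the limit leaves the size open), is none beyond the scatter. Compound 4 is expected to give about 100000 nM in this assay, within 40000 nM to 300000 nM, most likely reported as a limit once more.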

Compound 4, half-maximal inhibitory concentration: 3890 nM
The estimate for compound 4 lay 26-fold (1.41 log units) above the measured number; the measured number lies below the stated range.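

In this assay, going from 3-methoxyphenyl to phenyl brings an at least 25-fold lower number from compound 2 to compound 4 (1.41 log units; beyond the scatter), the first measurable activity in the series. A single methoxy on this aromatic carbon therefore separates a measured number from a limit, at least with the other aryl group of compound 2 in place. The true size of the step stays open, since most of the series gives only a limit: the limit of > 100000 nM in this assay, at which 3 of the 4 values shown sit.

Still open, on these data alone, is whether fluorine, a methyl group or an amine on this carbon would keep the number of compound 4. As far as these compounds go, it is also open whether the same change would lift compound 1 off its limit.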